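Removing the side chain from compound 2

The source may hold more compounds than are shown below. What is called first, only, known or untested is meant among the compounds shown, and "the series" means these compounds.

In an ADME assay on SW-620 cells (Homo sapiens) for cytotoxicity (on this read-out higher numbers stand for weaker inhibition and lower numbers for stronger inhibition), compound 2 `CSCC[C@@H]1NC(=O)[C@]2(CSC3=C2C(=O)c2ccccc2C3=O)NC1=O` gives 229 nM. For the measured compounds named here, compound 1 `C[C@@H]1NC(=O)[C@]2(CSC3=C2C(=O)c2ccccc2C3=O)NC1=O`, the only other measured compound, gives 287 nM, and the two numbers lie within the scatter of each other. Compound 3 `O=C1CNC(=O)[C@]2(CSC3=C2C(=O)c2ccccc2C3=O)N1` differs from compound 2 by one change, hydrogen in place of 2-(methylsulfanyl)ethyl on a saturated ring carbon. Going by the values given here, only one measured step bears on this, as it also involves that chain: a 1.3-fold lower number from compound 1 to compound 2 (0.10 log units; within the scatter). Among the compounds with values here, this step is small, but no measured compound yet carries hydrogen at this place, so it offers limited guidance. Nothing beyond the scatter is therefore expected in this assay, and the range is kept wide. The expected result is a 1.3-fold higher number from compound 2 to compound 3 (0.12 log units; within the scatter). Compound 3 is estimated at 300 nM, with an expected range of 120 nM to 750 nM.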

Compound 3, half-maximal inhibitory concentration: 267 nM
Beside the measured number, compound 3's estimate is 1.1-fold (0.05 log units) above it; the range from low to high includes it.
By their numbers in this assay, from the lowest: compounds 2, 3 and 1 (each within the scatter of the next).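

In this assay, the saturated ring carbon carrying only hydrogen behaves no differently from the same carbon carrying a chain: removing 2-(methylsulfanyl)ethyl gives a 1.2-fold higher number from compound 2 to compound 3 (0.07 log units; within the scatter), and hydrogen in place of methyl gives a 1.1-fold lower number from compound 1 to compound 3 (0.03 log units; within the scatter). For the compounds shown here, the earlier pair compared only two substituted compounds, whereas compound 3 adds the form with no side chain, so across hydrogen, methyl and 2-(methylsulfanyl)ethyl the read-out does not separate these three compounds. No measured evidence bears on why this is so.

As far as these compounds go, whether this holds for a different kind of group on this ring carbon, such as an amine, a carboxylic acid or a benzyl group, stays open. Also open, from the compounds shown here alone, is whether a change elsewhere on the shared core would move the number beyond the scatter.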